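This account rests on a few compounds, and the source may have more. Where it says the series, first, only, none or still open, it means among the compounds named here.

Measured compounds in a functional assay on IMR-32 cells for inhibition of Voltage-dependent N-type calcium channel subunit alpha-1B (Homo sapiens), read by calcium flux; a lower number here means a stronger inhibitor, a higher number a weaker inhibitor:

Compound 1, `CC1=NC(C)=C(C(=O)O)C(c2ccc([N+](=O)[O-])cc2)/C1=C(\O)OC/C=C/c1ccccc1`, gives 21000 nM.
Compound 2, `COC(=O)c1cccc(C2C(C(=O)O)=C(C)N=C(C)/C2=C(/O)OC/C=C/c2ccccc2)c1`, gives 4600 nM.
Compound 3, `CC1=NC(C)=C(C(=O)O)C(c2cccc(Cl)c2)/C1=C(\O)OC/C=C/c1ccccc1`, gives 1000 nM.

Compound 3 has the lowest number of the three. The nearest is compound 2, and the step of a 4.6-fold lower number from compound 2 to compound 3 (0.66 log units; beyond the scatter) lies beyond the scatter. The furthest is compound 1, and the step of a 21-fold lower number from compound 1 to compound 3 (1.32 log units; beyond the scatter) is large. Both measured steps that lead to compound 3 replace one whole group on the saturated ring carbon with another, as does a 4.6-fold lower number from compound 1 to compound 2 (0.66 log units; beyond the scatter).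

Compound 4 is `CC1=NC(C)=C(C(=O)O)C(c2cccc(Br)c2)/C1=C(\O)OC/C=C/c1ccccc1`. It differs from compound 3 in one place: bromo in place of chloro on an aromatic carbon. For the measured compounds named here, no measured step exchanges one halogen for another, so none of the three steps speaks directly to this change; they only show that the group on this phenyl ring can move this assay by a modest to large amount when it is changed more thoroughly. Exchanging chloro for bromo is a much smaller change than any of those, and the expectation is a step within the scatter, a 1.3-fold lower number from compound 3 to compound 4 (0.10 log units; within the scatter), in either direction.

Compound 4 is therefore estimated at 800 nM, with a likely range from 300 nM to 2500 nM.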

Compound 4, half-maximal inhibitory concentration: 790 nM
Beside the measured number, compound 4's estimate is 1.0-fold (0.01 log units) above it; measured number inside the range.
By their numbers in this assay, from the lowest: compounds 4 and 3 (each within the scatter of the next); then compound 2; then compound 1.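

In this assay, for the compounds shown here, the exchange of one halogen for another gives a 1.3-fold lower number from compound 3 to compound 4 (0.10 log units; within the scatter) and so shows, as the earlier compounds could not, that this assay does not separate chloro from bromo on this ring. Bromo also stands apart from the other groups, with a 5.8-fold lower number from compound 2 to compound 4 (0.77 log units; beyond the scatter) when it replaces methoxycarbonyl on the same aromatic carbon, and with a 27-fold lower number from compound 1 to compound 4 (1.42 log units; beyond the scatter) when 3-bromophenyl replaces 4-nitrophenyl, so the earlier gains are not unique to chloro. Nothing shown here accounts for the close agreement between the two halogens.

The compounds shown leave open whether a smaller or larger replacement at this place, such as fluoro, iodo, methyl or an amine, would also match chloro and bromo or would move the number away from them. Going by these compounds alone, they also leave open how much of the step between 4-nitrophenyl and 3-bromophenyl comes from the change of group and how much from its place on the ring, since no pair here has the same group at two different places.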